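The compounds below may be only part of what the source reports. "The series", "measured", "known", "first", "only" and "open" are said of these compounds alone.

Measured so far in a functional assay on CHO-K1 cells for agonist activity at Glucose-dependent insulinotropic receptor (Homo sapiens), read by a luciferase reporter, with a stated time of 5 h; on this read-out lower numbers stand for an effect already at smaller amounts and higher numbers for an effect only at larger amounts of compound:

Compound 1 `CC(=O)N1CCN(c2ccc(OCC3CCN(C(=O)OC(C)C)CC3)cn2)CC1`: for compound 1 this assay gives only a limit, > 10000 nM.
Compound 2 `CC(C)OC(=O)N1CCC(COc2ccc(N3CCN(C(=O)c4ccco4)CC3)nc2)CC1`: compound 2 gives 1900 nM.
Compound 3 `CC(C)OC(=O)N1CCC(COc2ccc(N3CCN(S(=O)(=O)C4CCCCC4)CC3)nc2)CC1`: compound 3 gives 200 nM.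

Compound 3 thus holds the lowest of the two numbers in this assay; its nearest neighbour is compound 2, separated by a 9.5-fold lower number from compound 2 to compound 3 (0.98 log units; beyond the scatter), while compound 1 sits at the assay limit (the limit of > 10000 nM in this assay, at which 1 of the 3 values shown sits). Compound 4 `CC(C)OC(=O)N1CCC(COc2ccc(N3CCN(S(=O)(=O)c4cccs4)CC3)nc2)CC1` differs from compound 3 in one place: thiophen-2-yl in place of cyclohexyl on a sulfonyl sulfur. Among the compounds with values here, none of the measured steps alters a group on the sulfonyl sulfur itself. The steps of an at least 5.2-fold lower number from compound 1 to compound 2 (0.72 log units; beyond the scatter), an at least 50-fold lower number from compound 1 to compound 3 (1.69 log units; beyond the scatter) and a 9.5-fold lower number from compound 2 to compound 3 (0.98 log units; beyond the scatter) each exchange the whole group on the ring nitrogen, so they bear on the new change only indirectly: they show that the sulfonyl-bearing compound 3 gave the lowest number and that a five-membered aromatic ring on a carbonyl, in compound 2, gave a higher number than the cyclohexyl on a sulfonyl in compound 3. Keeping the sulfonyl while swapping cyclohexyl for thiophen-2-yl is therefore expected to cost little, and compound 4 is expected to show a 2.0-fold higher number from compound 3 to compound 4 (0.30 log units; within the scatter), a step at the edge of the scatter toward a higher number. The estimate for compound 4 in this assay is 400 nM, expected to fall between 120 nM and 1500 nM.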

Compound 4, half-maximal effective concentration: 1800 nM
For compound 4 the middle estimate is 4.5-fold (0.65 log units) below the measured one; measured number above the stated range.
By their numbers in this assay, from the lowest: compound 3; then compounds 4 and 2 (each within the scatter of the next). At a limit, above all of these: compound 1.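

In this assay, the group on the sulfonyl sulfur proves to matter in its own right: a 9.0-fold higher number from compound 3 to compound 4 (0.95 log units; beyond the scatter), so keeping the sulfonyl does not by itself preserve the number of compound 3. With a five-membered aromatic ring attached, the (thiophen-2-yl)sulfonyl and (furan-2-yl)carbonyl groups on the amine nitrogen in a ring are not told apart, with a 1.1-fold lower number from compound 2 to compound 4 (0.02 log units; within the scatter), so in this pair the sulfonyl shows no advantage over the carbonyl. Compound 1 stands at a limit, so an at least 5.5-fold lower number from compound 1 to compound 4 (0.74 log units; beyond the scatter) gives only a bound on the step to the (thiophen-2-yl)sulfonyl group: the limit of > 10000 nM in this assay, at which 1 of the 4 values shown sits.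

Cyclohexyl and thiophen-2-yl differ at once in ring size, in aromatic character and in the sulfur atom, so these compounds leave open which of these differences goes with the step; a phenyl or a cyclopentyl group on the sulfonyl sulfur would begin to separate them. As far as these compounds go, it also remains open whether cyclohexyl on a carbonyl carbon would give a number like that of compound 3, which would show whether the low number depends on the sulfonyl or on the cyclohexyl alone.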